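The source may report more compounds than this note shows. Statements on the series, on what has been measured and on what is new or still open speak of the compounds shown alone.

Measured so far:
- compound 2 `CN(C)CCn1cnnc1-c1cc(Oc2ccc(NC(=O)N/N=C/c3cccc(Cl)c3Cl)cc2F)ccn1`: 6130 nM
- compound 3 `CN(C)CCn1cnnc1-c1cc(Oc2ccc(NC(=O)N/N=C/c3c(O)ccc4ccccc34)cc2F)ccn1`: 3250 nM
- compound 1 `CN(C)CCn1cnnc1-c1cc(Oc2ccc(NC(=O)N/N=C/c3cccc(O)c3)cc2F)ccn1`: "not determined" (no result reported)

In an ADME assay on WI-38 cells (Homo sapiens) for cytotoxicity, read by MTT assay, with a stated time of 72 h (on this read-out higher numbers stand for weaker inhibition and lower numbers for stronger inhibition), compound 2 gives 6130 nM, the highest of the two numbers shown; compound 3 gives 3250 nM, and the step of a 1.9-fold lower number from compound 2 to compound 3 (0.28 log units; within the scatter) lies within the scatter, so the two cannot be ordered. Compound 1 has no result in this assay.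

Compound 4 `CN(C)CCn1cnnc1-c1cc(Oc2ccc(NC(=O)N/N=C/c3ccccc3O[N+](=O)[O-])cc2F)ccn1` differs from compound 2 by one change: 2-(nitrooxy)phenyl in place of 2,3-dichlorophenyl on a carbon with a double bond to nitrogen. Going by the values given here, the only step bearing on this position is a 1.9-fold lower number from compound 2 to compound 3 (0.28 log units; within the scatter), a different group at the same place, which produced no change beyond the scatter. On that basis no step beyond the scatter is expected for compound 4 either, and its number in this assay is estimated to be 5000 nM, between 1800 nM and 14000 nM, meaning an expected step of a 1.2-fold lower number from compound 2 to compound 4 (0.09 log units; within the scatter).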

Compound 4, half-maximal inhibitory concentration: 6860 nM
Estimate against measurement, compound 4: 1.4-fold (0.14 log units) below; low and high end bracket the measured number.
By their numbers in this assay, from the lowest: compounds 3, 2 and 4 (each within the scatter of the next, the first and the last beyond it).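

In this assay, the step for 2-(nitrooxy)phenyl in place of 2,3-dichlorophenyl is a 1.1-fold higher number from compound 2 to compound 4 (0.05 log units; within the scatter) and so gives no order between these two groups on the carbon with a double bond to nitrogen. Against 2-hydroxynaphthalen-1-yl, the step is a 2.1-fold higher number from compound 3 to compound 4 (0.32 log units; beyond the scatter) and is the first at this position to lie beyond the scatter, though only modestly. No measurement shown accounts for this step.

The compounds shown leave open how an amine or a carboxylic acid on the phenyl ring at this place would read out.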